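The source may report more compounds than this note shows. Statements on the series, on what has been measured and on what is new or still open speak of the compounds shown alone.

Measured so far:
compound 1 `CCOC(=O)/C=C/C1=CC[C@H]2C(C)(C)CCC[C@]2(C)[C@H]1C=O`: 29000 nM
compound 2 `CC(C)(C)OC(=O)/C=C/C1=CC[C@H]2C(C)(C)CCC[C@]2(C)[C@H]1C=O`: 29000 nM

In a functional assay on Hs 683 cells (Homo sapiens) for inhibition, read by MTT assay, with a stated time of 72 h (on this read-out lower numbers stand for stronger inhibition of growth and higher numbers for weaker inhibition of growth), compound 2 gives 29000 nM, level with compound 1 at the digits shown. Compound 3 `CC1(C)CCC[C@]2(C)[C@@H](C=O)C(/C=C/C(=O)OCc3ccccc3)=CC[C@@H]12` has not yet been measured. It carries benzyl in place of tert-butyl on an oxygen next to a carbonyl group. The incoming group brings one six-membered aromatic ring of carbon only, which neither measured compound has at this place. Among the compounds with values here, only one measured step bears on the change: no change at the digits printed from compound 1 to compound 2 (within the scatter), with tert-butyl in place of ethyl on the same oxygen. That step stayed within the scatter, although a single step says little about an aromatic ring. The data therefore give no reason to expect a shift in either direction in this assay. The expected move is a 1.2-fold lower number from compound 2 to compound 3 (0.06 log units; within the scatter), nothing beyond the scatter. For compound 3 the estimated value is 25000 nM, with an expected range from 12000 nM to 50000 nM.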

Compound 3, concentration for 50% growth inhibition: 31000 nM
Compound 3: the middle estimate sits 1.2-fold (0.09 log units) below what was measured; low and high end bracket the measured number.
By their numbers in this assay, from the lowest: compounds 1, 2 and 3 (each within the scatter of the next).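

Within the data shown here, with benzyl on the oxygen next to a carbonyl group, a six-membered aromatic ring of carbon only comes to this place for the first time, and this assay shows a 1.1-fold higher number from compound 2 to compound 3 (0.03 log units; within the scatter) and a 1.1-fold higher number from compound 1 to compound 3 (0.03 log units; within the scatter) in the same read-out. Ethyl, tert-butyl and benzyl thus all sit within the scatter of one another, with none of the three compounds going against this, whereas the earlier pair held only open-chain groups here and could not show that an aromatic ring also leaves the number unmoved. Nothing measured here explains why the read-out stays level.

On these data alone, whether a carboxylic acid or an amide in place of these esters would move the number beyond the scatter remains open. So does the effect of an amine or a hydroxyl group on the benzyl ring.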